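Imidazolyl for cyclopentyl at the dioxolane-side chain: expectation

The source may report more compounds than this note shows. Statements on the series, on what has been measured and on what is new or still open speak of the compounds shown alone.

Compound 1 `CCC(C)n1ncn(-c2ccc(N3CCN(c4ccc(OC[C@@H]5CO[C@@](CC6CCCC6)(c6ccc(Cl)cc6Cl)O5)cc4)CC3)cc2)c1=O` is the reference of this pair. Within the data shown here, in a functional assay on HUVEC cells (Homo sapiens), read by scintillation counting and thymidine incorporation, with a stated time of 24 h (on this read-out lower numbers stand for stronger inhibition and higher numbers for weaker inhibition), compound 1 gives 512 nM, the lower of the two numbers measured so far; compound 2 `CCC(C)n1ncn(-c2ccc(N3CCN(c4ccc(OC[C@@H]5CO[C@@](CN(C)C)(c6ccc(Cl)cc6Cl)O5)cc4)CC3)cc2)c1=O` gives 1400 nM. Among the measured compounds shown here, the one measured step, a 2.7-fold higher number from compound 1 to compound 2 (0.44 log units; beyond the scatter), comes from the same position. Compound 3 `CCc1nccn1C[C@@]1(c2ccc(Cl)cc2Cl)OC[C@@H](COc2ccc(N3CCN(c4ccc(-n5cnn(C(C)CC)c5=O)cc4)CC3)cc2)O1` differs from compound 1 by 2-ethyl-1H-imidazol-1-yl in place of cyclopentyl on a saturated chain carbon bound to a saturated ring carbon. For the measured compounds named here, the only bearing step is the one to compound 2, modest and weakening, so a weakening of similar size is expected here, a 2.0-fold higher number from compound 1 to compound 3 (0.29 log units; within the scatter). Compound 3 is therefore estimated at 1000 nM, with a range of 400 nM to 2500 nM.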

Compound 3, half-maximal inhibitory concentration: 224 nM
Estimate against measurement, compound 3: 4.5-fold (0.65 log units) above; measured number outside the range, below it.
By their numbers in this assay, from the lowest: compound 3; then compound 1; then compound 2.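

Replacing cyclopentyl at this position does not always weaken the result: in this assay the change to 2-ethyl-1H-imidazol-1-yl gives a 2.3-fold lower number from compound 1 to compound 3 (0.36 log units; beyond the scatter) and runs against the dimethylamino step. The two nitrogen-bearing groups also differ from each other, with a 6.3-fold lower number from compound 2 to compound 3 (0.80 log units; beyond the scatter) as the measured gap, so nitrogen in the entering group does not alone set the direction here. No measurement given here accounts for this difference.

On these data alone, whether the gain belongs to the imidazole ring or to its ethyl group remains open. An unsubstituted 1H-imidazol-1-yl or a 1H-1,2,4-triazol-1-yl group on the same chain carbon would help separate the two.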